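A few compounds are considered here, and "the series" means these few. Any claim that something is new, unique, unknown or untested is made for them only; others in the source may bear on it.

Working notes on the series. Compound 1 `COc1cc(/C=C/C(=O)/C=C(/C=C/c2ccc(O)c(OC)c2)NCCCO)ccc1O` and compound 2 `O=C(/C=C(/C=C/c1ccc(O)cc1)NCCO)/C=C/c1ccc(O)cc1` are the two compounds measured in an ADME assay on CHO-K1 cells (Cricetulus griseus) for activation, read by fluorescence, tested at 10 uM; on this read-out higher numbers stand for a weaker effect at the one concentration tested and lower numbers for a stronger effect. In this assay, within the data shown here, compound 1 gives 89.9%; in this assay compound 2 gives 85.7%, a number that does not lie beyond the scatter from compound 1, so the two stand together at the weak end of the read-out, and no step between them is drawn. Compound 3 `COCCCNC(=C\C(=O)/C=C/c1ccc(O)c(OC)c1)/C=C/c1ccc(O)c(OC)c1` is not yet measured and is reached from compound 1 by one change: methyl in place of hydrogen on an oxygen on a saturated carbon. Among the measured compounds shown here, no measured pair carries this change, so there is no precedent for its size; both measured numbers sit high and close together, and the change adds a single carbon on the oxygen of the chain. The step from compound 1 to compound 3 is expected to be small, a number 1.9 percentage points lower from compound 1 to compound 3 (within the scatter), with no move beyond the scatter expected in this assay. Compound 3 is estimated at 88% in this assay, with a range from 75% to 99%.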

Compound 3, a percentage reported as activity, at one concentration (the size of the read-out at that concentration, not a potency): 81.2%
Beside the measured number, compound 3's estimate is 6.8 percentage points above it; the measured number falls inside the stated range.
By their numbers in this assay, from the lowest: compounds 3, 2 and 1 (each within the scatter of the next).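

In this assay, the change from hydroxy to methoxy on an oxygen on a saturated carbon now has a measured size, a number 8.7 percentage points lower from compound 1 to compound 3 (within the scatter), and that step stays within the scatter. The hydrogen on this oxygen is therefore not needed to hold the read-out where it stands, and capping it with methyl does not separate compound 3 from compound 1. Nothing available bears on why the step has this size. As far as these compounds go, whether an ethyl group on this oxygen, or an amine or a carboxylic acid in place of the hydroxy, would move the read-out beyond the scatter remains open. Also open, from the compounds shown here alone, is whether the same change on the 2-hydroxyethyl chain of compound 2 would give a step of similar size.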